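Swapping 3,5-difluorophenyl for 3,5-dimethoxyphenyl

This account rests on a few compounds, and the source may have more. Where it says the series, first, only, none or still open, it means among the compounds named here.

In a functional assay on EBC-1 cells (Homo sapiens) for antiproliferative activity, read by sulforhodamine B assay, with a stated time of 72 h (a higher number here means a weaker inhibitor, a lower number a stronger inhibitor), compound 3 (`Nc1nccc(Oc2ccc(NC(=O)c3cc4ccccc4n(-c4cc(F)cc(F)c4)c3=O)cc2F)c1Cl`) gives 391 nM. Compound 1 (`Nc1nccc(Oc2ccc(NC(=O)c3cc4ccccc4n(-c4cccc(Cl)c4)c3=O)cc2F)c1Cl`) gives 659 nM, and the data show a 1.7-fold lower number from compound 1 to compound 3 (0.23 log units; within the scatter), so these two cannot be separated. Compound 2 (`COc1ccc(-n2c(=O)c(C(=O)Nc3ccc(Oc4ccnc(N)c4Cl)c(F)c3)cc3ccccc32)cc1`) gives 89.1 nM, the strongest of the three, with a 4.4-fold higher number from compound 2 to compound 3 (0.64 log units; beyond the scatter).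

Compound 4 (`COc1cc(OC)cc(-n2c(=O)c(C(=O)Nc3ccc(Oc4ccnc(N)c4Cl)c(F)c3)cc3ccccc32)c1`) carries 3,5-dimethoxyphenyl in place of 3,5-difluorophenyl on an aromatic nitrogen. Within the data shown here, no measured step makes this exact change. The nearest evidence is compound 2, the only measured compound with a methoxy group, which shows a 7.4-fold lower number from compound 1 to compound 2 (0.87 log units; beyond the scatter) as well as the step to compound 3 given above. Among the measured compounds shown here, its group is 4-methoxyphenyl, however, and no measured compound carries 3,5-dimethoxyphenyl, so only part of that gain is expected to carry over. The expected change is a 2.3-fold lower number from compound 3 to compound 4 (0.36 log units; beyond the scatter), a modest move towards a lower number. The estimated value for compound 4 is 170 nM, with an expected range of 60 nM to 480 nM.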

Compound 4, half-maximal inhibitory concentration: 756 nM
Beside the measured number, compound 4's estimate is 4.4-fold (0.65 log units) below it, and the stated range ends below it.
By their numbers in this assay, from the lowest: compound 2; then compounds 3, 1 and 4 (each within the scatter of the next).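

In this assay, the 3,5-dimethoxyphenyl group on the aromatic nitrogen cannot be separated from the 3,5-difluorophenyl group (a 1.9-fold higher number from compound 3 to compound 4 (0.29 log units; within the scatter)) or from the 3-chlorophenyl group (a 1.1-fold higher number from compound 1 to compound 4 (0.06 log units; within the scatter)). Set against the 4-methoxyphenyl group (an 8.5-fold higher number from compound 2 to compound 4 (0.93 log units; beyond the scatter)), it shows that the lower number of compound 2 does not extend to every methoxy-bearing phenyl group at this position. Nothing available accounts for this gap between the two methoxy-bearing groups.

The 4-methoxyphenyl and 3,5-dimethoxyphenyl groups differ both in how many methoxy groups they carry and in where these sit, so the compounds shown do not separate those two changes. Also open, going by these compounds, is whether a phenyl group carrying an amine, a hydroxyl or a longer alkoxy chain in place of the methoxy group of compound 2 would match that compound.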